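Swapping the Piperazine Substituent Back to a Direct Aryl

The source may hold more compounds than are shown below. What is called first, only, known or untested is meant among the compounds shown, and "the series" means these compounds.

Compound 3 `Nc1scc(CN2CCN(CCCc3ccc(Cl)cc3)CC2)c1C(=O)c1ccc(Cl)cc1` shows the highest number of the three measured compounds in a functional assay on CHO cells with adenosine receptor A1 (Homo sapiens) as the target, read by cAMP accumulation and immunoassay, with a stated time of 6 min, tested at 1 uM (on this read-out lower numbers stand for a stronger effect and higher numbers for a weaker effect at the one concentration tested), with a value of -30%. Compound 1 `Nc1scc(CN2CCN(c3ccc(Cl)cc3F)CC2)c1C(=O)c1ccc(Cl)cc1` gives -57% and compound 2 `Nc1scc(CN2CCN(c3cccc(F)c3F)CC2)c1C(=O)c1ccc(Cl)cc1` gives -66% in this assay; the step of a number 9 percentage points lower from compound 1 to compound 2 (within the scatter) lies within the scatter, while the steps of a number 27 percentage points higher from compound 1 to compound 3 (beyond the scatter) and a number 36 percentage points higher from compound 2 to compound 3 (beyond the scatter) are both beyond it. In both of those steps an aryl group attached directly to the ring nitrogen was exchanged for 3-(4-chlorophenyl)propyl, and the number rose each time.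

Compound 4 `Nc1scc(CN2CCN(c3ccc(Cl)c(Cl)c3)CC2)c1C(=O)c1ccc(Cl)cc1` reverses that kind of change: 3,4-dichlorophenyl in place of 3-(4-chlorophenyl)propyl on an amine nitrogen in a ring. Because the steps of a number 27 percentage points higher from compound 1 to compound 3 (beyond the scatter) and a number 36 percentage points higher from compound 2 to compound 3 (beyond the scatter) both moved upward when the directly attached aryl group was replaced, the return to a directly attached aryl group in compound 4 is expected to move the number back down, with an estimated step of a number 30 percentage points lower from compound 3 to compound 4 (beyond the scatter). For compound 4 the expected value in this assay is -60%, within a range from -80% to -38%.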

Compound 4, a percentage reported as activity, at one concentration (the size of the read-out at that concentration, not a potency): -60%
Compound 4: middle estimate and measured number agree at the digits printed; the measured number falls inside the stated range.
By their numbers in this assay, from the lowest: compounds 2, 4 and 1 (each within the scatter of the next); then compound 3.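

The step of a number 30 percentage points lower from compound 3 to compound 4 (beyond the scatter) in this assay shows that a directly attached aryl group carrying two chlorines and no fluorine also stands apart from the 3-(4-chlorophenyl)propyl group of compound 3. The steps of a number 6 percentage points higher from compound 2 to compound 4 (within the scatter) and a number 3 percentage points lower from compound 1 to compound 4 (within the scatter) show that the three halogen patterns on directly attached aryl groups cannot be told apart here, which leaves compound 3 alone among the four compounds. No measurement here explains either the gap to compound 3 or the absence of a gap among the other three compounds.

Every aryl group shown carries only halogens, so a methoxy group, a nitrile or an unsubstituted phenyl remains open. The single chain shown also leaves open how a benzyl group or a 2-phenylethyl group would compare.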